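Urea and thiourea pairs with two alternative aryl groups

The source may hold more compounds than are shown below. What is called first, only, known or untested is meant among the compounds shown, and "the series" means these compounds.

Measured so far in a functional assay, with a stated time of 20 min, tested at 10 uM; a higher number here means a stronger effect of the compound at the concentration tested, a lower number a weaker effect:
compound 1 `COc1cc(/C=C/C(=O)C2=C(/C=C/c3ccc(O)c(OC)c3)NC(=O)NC2c2ccc(N(C)C)cc2)ccc1O` gives 37.6%
compound 2 `COc1cc(/C=C/C(=O)C2=C(/C=C/c3ccc(O)c(OC)c3)NC(=O)NC2c2c(Cl)cccc2Cl)ccc1O` gives 19.2%
compound 3 `COc1cc(/C=C/C(=O)C2=C(/C=C/c3ccc(O)c(OC)c3)NC(=S)NC2c2ccc(N(C)C)cc2)ccc1O` gives 72%

Compound 1 and compound 3 differ in their cores; that difference is not broken down here. Compound 3 stands highest of the three, with compound 1 nearest and compound 2 furthest, both gaps beyond the scatter.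

Going by the values given here, the one counted change is 2,6-dichlorophenyl in place of 4-(dimethylamino)phenyl on a saturated ring carbon, and it made the step of a number 18.4 percentage points lower from compound 1 to compound 2 (beyond the scatter) in this assay.

Compound 4 `COc1cc(/C=C/C(=O)C2=C(/C=C/c3ccc(O)c(OC)c3)NC(=S)NC2c2c(Cl)cccc2Cl)ccc1O` is not yet measured. It differs from compound 3 by 2,6-dichlorophenyl in place of 4-(dimethylamino)phenyl on a saturated ring carbon, the same change as from compound 1 to compound 2, made on the core of compound 3. Among the compounds with values here, the expected step is a number 19 percentage points lower from compound 3 to compound 4 (beyond the scatter), of about the size seen from compound 1 to compound 2, because a number 18.4 percentage points lower from compound 1 to compound 2 (beyond the scatter) is the only instance of this change so far and rests on one pair alone. Compound 4 is therefore estimated to give 53% in this assay, with an expected range from 35% to 70%.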

Compound 4, a percentage reported as activity, at one concentration (the size of the read-out at that concentration, not a potency): 29%
For compound 4 the middle estimate is 24 percentage points above the measured one, outside the stated range (below it).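

In this assay, 2,6-dichlorophenyl in place of 4-(dimethylamino)phenyl on the saturated ring carbon again goes downward, giving a number 43 percentage points lower from compound 3 to compound 4 (beyond the scatter). The direction of the change carries from the core of compound 1 to the core of compound 3, but its size does not: the same change on two cores in this assay, a number 18.4 percentage points lower (beyond the scatter) from compound 1 to compound 2 and a number 43 percentage points lower (beyond the scatter) from compound 3 to compound 4, 24.6 percentage points apart, beyond the scatter of two such steps. A step measured on one core therefore cannot be used as a fixed increment on the other, although two pairs do not show why the size differs or what the step would be on any further core.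

The compounds shown leave open whether the step follows the departure of the dimethylamino group or the arrival of the two chlorine atoms, which a plain phenyl group or a phenyl group bearing a single chlorine on both cores would help separate. Also open, from the compounds shown here alone, is whether the 2-(4-hydroxy-3-methoxyphenyl)ethenyl group, common to all four compounds, has any bearing on the size of the step.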